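Aryl group exchange at the benzylic ring of the series

The compounds below may be only part of what the source reports. "The series", "measured", "known", "first", "only" and "open" are said of these compounds alone.

Measured compounds:
compound 1: `CCOc1cccc(-c2ccc(CN(C(=O)C3CCCCC3)c3cccc(/C=C/C(=O)OC)c3)cc2)c1`; in an assay on isolated protein with Bile acid receptor (Homo sapiens) as the target (on this read-out higher numbers stand for an effect only at larger amounts of compound and lower numbers for an effect already at smaller amounts), compound 1 gives 147 nM.
compound 2: `COC(=O)/C=C/c1cccc(N(Cc2ccc(/C=C/c3c(Cl)cccc3Cl)cc2)C(=O)C2CCCCC2)c1`; in this assay compound 2 gives 150 nM.

Within the data shown here, compound 2 and compound 1 lie within the scatter of each other: the single step, a 1.0-fold higher number from compound 1 to compound 2 (0.01 log units; within the scatter), shows that exchanging 3-ethoxyphenyl for 2-(2,6-dichlorophenyl)ethenyl left the read-out where it was. Compound 2 therefore stands alongside compound 1 with no separation between the two numbers.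

Compound 3 `COC(=O)/C=C/c1cccc(N(Cc2ccc(-c3cc(Cl)ccc3OC)cc2)C(=O)C2CCCCC2)c1` is not yet measured. Relative to compound 2 the change is 5-chloro-2-methoxyphenyl in place of 2-(2,6-dichlorophenyl)ethenyl on an aromatic carbon. Among the measured compounds shown here, the only measured step that bears on this change is a 1.0-fold higher number from compound 1 to compound 2 (0.01 log units; within the scatter), which swapped one group carrying a six-membered aromatic ring of carbon only for another at the same place and produced no shift beyond the scatter. Compound 3 returns to a directly attached aromatic ring, as in compound 1, so on the evidence of that step no step beyond the scatter is expected in this assay, in either direction, and the expected step is no change at the digits printed from compound 2 to compound 3 (within the scatter). Compound 3 is accordingly estimated at 150 nM, with a range of 60 nM to 400 nM.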

Compound 3, half-maximal effective concentration: 233 nM
Compound 3: middle estimate off by 1.6-fold (0.19 log units), on the low side; the measured number falls inside the stated range.
By their numbers in this assay, from the lowest: compounds 1, 2 and 3 (each within the scatter of the next).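

In this assay, a 1.6-fold higher number from compound 2 to compound 3 (0.19 log units; within the scatter) and a 1.6-fold higher number from compound 1 to compound 3 (0.20 log units; within the scatter) extend the picture to a third group at this place, para to a large group, with all three compounds within the scatter of one another. This assay does not separate directly attached 5-chloro-2-methoxyphenyl from directly attached 3-ethoxyphenyl, nor from 2-(2,6-dichlorophenyl)ethenyl with its double bond outside aromatic rings. The exchange of 2-(2,6-dichlorophenyl)ethenyl for 5-chloro-2-methoxyphenyl brings in one hydrogen-bond acceptor and removes that double bond, yet across these compounds neither feature is tied to a step beyond the scatter.

All three groups carry one six-membered aromatic ring of carbon only, so it remains open whether a carboxylic acid, an amine or a plain alkyl chain at this place would stay within the scatter of these compounds. On these data alone, it is also open whether the read-out would remain as flat with another part of the shared core altered, as all three compounds carry that core unchanged.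

No measurement at hand accounts for the close agreement of these three compounds.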